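Chloro to methyl swap on the aniline ring of compound 3

A few compounds are considered here, and "the series" means these few. Any claim that something is new, unique, unknown or untested is made for them only; others in the source may bear on it.

Measured compounds in the series:
- compound 1 `Cc1ccc(NC(C(=O)CCc2ccncc2)c2ccccc2C(C)C)c(Cl)c1`: 3300 nM
- compound 2 `Cc1ccc(NC(C(=O)CCc2ccncc2)c2ccccc2C)c(F)c1`: 439 nM
- compound 3 `Cc1ccccc1C(Nc1ccc(Cl)cc1C(F)(F)F)C(=O)CCc1ccncc1`: 469 nM

All three were run in an assay on isolated protein for binding affinity to corticotropin-releasing factor receptor 1 (Homo sapiens); on this read-out lower numbers stand for stronger inhibition and higher numbers for weaker inhibition. Among the three numbers, compound 3 gives 469 nM, the second highest of the set. Its nearest neighbour is compound 2 at 439 nM, a gap that sits within the scatter, so no order between compound 2 and compound 3 can be claimed. The furthest value is that of compound 1 at 3300 nM, which lies beyond the scatter above compound 3.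

Compound 4 `Cc1ccc(NC(C(=O)CCc2ccncc2)c2ccccc2C)c(C(F)(F)F)c1` has not yet been measured in this assay. It differs from compound 3 in one place: methyl in place of chloro on an aromatic carbon. The ring that carries the change keeps its trifluoromethyl group; the rest of the shared core, including the pyridine-bearing chain and the ortho-methyl phenyl, is unchanged.

Within the data shown here, no directly comparable pair exists among the measured compounds, so the step can only be judged from the structural change itself. A chloro to methyl exchange on an aromatic carbon of this kind is expected to move this assay little, and the step from compound 3 to compound 4 is estimated at a 1.0-fold lower number from compound 3 to compound 4 (0.02 log units; within the scatter), a change not clearly beyond the scatter in either direction. Compound 4 is therefore expected to give about 450 nM, with a plausible range from 200 nM to 1100 nM.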

Compound 4, inhibition constant: 641 nM
Estimate against measurement, compound 4: 1.4-fold (0.15 log units) below, and the stated range covers the measured number.
By their numbers in this assay, from the lowest: compounds 2, 3 and 4 (each within the scatter of the next); then compound 1.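

Among these compounds, compound 4 supplies the first single-place comparisons, and in this assay it connects compound 2 and compound 3, which differ in two places. On the aromatic carbon that is meta to a trifluoromethyl group and para to a large group, methyl in place of chloro gives a 1.4-fold higher number from compound 3 to compound 4 (0.14 log units; within the scatter) and so leaves the read-out within the scatter, which means this assay does not separate these two substituents here. The second change, at the other substituted carbon of the same ring, gives a 1.5-fold higher number from compound 2 to compound 4 (0.16 log units; within the scatter) for trifluoromethyl in place of fluoro, so that exchange is also not resolved, and neither step shows this ring to be a place where the number moves beyond the scatter when one of these small groups is swapped.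

As far as these compounds go, it remains open whether a methoxy group or an amine on the chloro-bearing carbon would move the number beyond the scatter, and compound 1 still has no single-place link to the other compounds, so its higher value cannot be assigned to either of its differences. Nothing available bears on why these two exchanges stay within the scatter.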